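A Chain Amine Swap on a Shared Core

A few compounds are considered here, and "the series" means these few. Any claim that something is new, unique, unknown or untested is made for them only; others in the source may bear on it.

Three compounds have numbers in a functional assay on SK-BR-3 cells (Homo sapiens) for antiproliferative activity; a higher number here means a weaker inhibitor, a lower number a stronger inhibitor. Compound 1 `CC(=O)Oc1ccc(C(=O)Nc2cc3ccc(OCC4CCCN(C)C4)c(C)c3oc2=O)cc1CC=C(C)C` gives 740 nM in this assay. Compound 2 `CC(=O)Oc1ccc(C(=O)Nc2cc3ccc(OCC4CCCNC4)c(C)c3oc2=O)cc1CC=C(C)C` keeps the whole of compound 1 apart from the amine nitrogen in the ring; in this assay compound 2 gives 620 nM. Compound 3 `CCCNCCCOc1ccc2cc(NC(=O)c3ccc(O)c(CC=C(C)C)c3)c(=O)oc2c1C` gives 990 nM, the highest of the three numbers, although its gaps to compound 1 and to compound 2 both lie within the scatter, so no order among the three can be read from them.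

Compound 4 `CC(C)=CCc1cc(C(=O)Nc2cc3ccc(OCCCN(C)c4ccccc4)c(C)c3oc2=O)ccc1O` is the next compound, and it differs from compound 3 in one place: methyl(phenyl)amino in place of propylamino on a saturated chain carbon, three bonds along the chain from an oxygen on an aromatic ring. Among the measured compounds shown here, only one measured step touches an amine nitrogen, a 1.2-fold lower number from compound 1 to compound 2 (0.08 log units; within the scatter), and that step left the number where it was. For the measured compounds named here, it is, however, a small exchange on a ring amine, whereas the present change brings in a six-membered aromatic ring on a chain amine and removes the hydrogen-bond donor there; no measured step shows what an aromatic ring entering at this place does. Going by the values given here, with the one related step flat, the expectation for compound 4 is a step of a 1.0-fold higher number from compound 3 to compound 4 (0.00 log units; within the scatter), not beyond the scatter, but with a wide range to allow for the untested ring. Compound 4 is therefore estimated to give 1000 nM in this assay, expected to fall between 350 nM and 2800 nM.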

Compound 4, half-maximal inhibitory concentration: > 50000 nM
Compound 4: only a limit was reported; the forecaster's own chance of this, stated with the estimate: 5%; at least 50-fold (1.69 log units) between middle value and limit.
By their numbers in this assay, from the lowest: compounds 2, 1 and 3 (each within the scatter of the next). At a limit, above all of these: compound 4.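

Among the compounds shown here, on this chain, the amine group matters far more than the one earlier step could suggest. For the compounds shown here, the exchange of propylamino for methyl(phenyl)amino is a large step beyond the scatter (an at least 50-fold higher number from compound 3 to compound 4 (1.70 log units; beyond the scatter)), whereas the only earlier change at an amine nitrogen, on a ring amine, stayed within it (a 1.2-fold lower number from compound 1 to compound 2 (0.08 log units; within the scatter)). For compound 4 the read-out in this assay is a limit and not a number: the limit of > 50000 nM in this assay, at which 1 of the 4 values shown sits. The entering group brings one six-membered aromatic ring of carbon only and has 0 hydrogen-bond donors where propylamino has 1, and since both differences arrive in the same step, it cannot assign the change to either one.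

The compounds shown leave open whether phenylamino, which keeps the hydrogen on the amine nitrogen alongside the ring, or methyl(propyl)amino, which loses that hydrogen without any ring, would stay near compound 3 or fall with compound 4. They also leave open whether a longer chain carrying methyl(phenyl)amino, or a benzylamine in its place, would give a measurable number in this assay.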